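From 3,4-dichlorophenyl to 4-hydroxyphenyl: a small step expected

A few compounds are considered here, and "the series" means these few. Any claim that something is new, unique, unknown or untested is made for them only; others in the source may bear on it.

Measured in a functional assay on MCF7 cells (Homo sapiens); a higher number here means a weaker inhibitor of growth, a lower number a stronger inhibitor of growth:
- Compound 1 `O=S(=O)(/C=C/c1ccc(Cl)c(Cl)c1)Cc1ccc(Nc2ncnc3ccccc23)cc1` gives 28000 nM
- Compound 2 `O=S(=O)(/C=C/c1ccc(F)cc1Cl)Cc1ccc(Nc2ncnc3ccccc23)cc1` gives 21000 nM
- Compound 3 `O=S(=O)(/C=C/c1ccc(Cl)c(Cl)c1)Cc1ccc(Nc2ncnc3ccc(Br)cc23)cc1` gives 14000 nM

Compound 3 stands at 14000 nM and cannot be separated from the other two compounds on these numbers, since all three values lie within the usual scatter of one another. Compound 4 `O=S(=O)(/C=C/c1ccc(O)cc1)Cc1ccc(Nc2ncnc3ccc(Br)cc23)cc1` keeps the bromo of compound 3 and differs in one group, with 4-hydroxyphenyl in place of 3,4-dichlorophenyl on a double-bonded chain carbon bound to a double-bonded chain carbon. Within the data shown here, two measured steps bear on this change. The closer one exchanges the group at that same place, putting 2-chloro-4-fluorophenyl in place of 3,4-dichlorophenyl (a 1.3-fold lower number from compound 1 to compound 2 (0.12 log units; within the scatter)). The other puts bromo in place of hydrogen, a feature that compound 4 retains (a 2.0-fold lower number from compound 1 to compound 3 (0.30 log units; within the scatter)). Neither step moved the number beyond the scatter. Among the measured compounds shown here, no measured compound carries 4-hydroxyphenyl, so the data give no direction for this change and the range must stay wide. The expected change in this assay is therefore none beyond the scatter, an estimated step (a 1.1-fold higher number from compound 3 to compound 4 (0.03 log units; within the scatter)). Compound 4 is estimated at 15000 nM (expected range 5000 nM to 40000 nM).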

Compound 4, concentration for 50% growth inhibition: 32000 nM
Estimate against measurement, compound 4: 2.1-fold (0.33 log units) below; low and high end bracket the measured number.
By their numbers in this assay, from the lowest: compounds 3, 2, 1 and 4 (each within the scatter of the next, the first and the last beyond it).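

In this assay, putting 4-hydroxyphenyl in place of 3,4-dichlorophenyl on a double-bonded chain carbon bound to a double-bonded chain carbon gives a 2.3-fold higher number from compound 3 to compound 4 (0.36 log units; beyond the scatter), a modest change and the only step shown that lies beyond the scatter. Among these compounds, the earlier exchange at this place, a 1.3-fold lower number from compound 1 to compound 2 (0.12 log units; within the scatter), stayed within the scatter, so the new step is the first sign that the group held here can shift the number, and that the shift can run towards weaker growth inhibition. No measured information available here accounts for this step.

The compounds shown leave open whether the step follows from the loss of the two chlorines or from the arrival of the hydroxy group, as compound 4 differs from compound 3 in both at once, and a plain phenyl or a 4-methoxyphenyl at this place would be needed to separate the two. Going by these compounds, it also remains open whether the same exchange would give a step of similar size on the core without the bromo.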